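Swapping One Side Chain on Compound 1

This account rests on a few compounds, and the source may have more. Where it says the series, first, only, none or still open, it means among the compounds named here.

Compound 1 `Cc1ccc([C@H](C(=O)N(C)C)N2C(=O)[C@@H](C3Cc4ccccc4C3)NC(=O)[C@H]2CC(C)C)cn1` gives 26%
Compound 2 `CC[C@H](C)[C@@H]1C(=O)N[C@H](C2Cc3ccccc3C2)C(=O)N1[C@@H](C(=O)N(C)C)c1cnc(C)cc1C` gives 17%

In an in vivo ADME assay on the whole organism for pharmacokinetics, with Canis familiaris (Canis lupus familiaris) as the target, at a dose of 0.6 mg/kg by the oral route (on this read-out lower numbers stand for lower oral bioavailability and higher numbers for higher oral bioavailability), compound 1 and compound 2 lie within the usual scatter of each other, so neither can be ranked above the other. Compound 3 `CCC(CC)[C@@H]1C(=O)N[C@H](C2Cc3ccccc3C2)C(=O)N1[C@@H](C(=O)N(C)C)c1ccc(C)nc1` is still unmeasured. It differs from compound 1 in one place, with pentan-3-yl in place of isobutyl on a saturated ring carbon. Among the measured compounds shown here, no measured pair shows the effect of such a swap, so no change beyond the scatter is expected in this assay in either direction. The expected size of the change is small, with a number 4 percentage points lower from compound 1 to compound 3 (within the scatter) as the estimated step. Compound 3 is estimated at 22% (expected range 8% to 40%).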

Compound 3, oral bioavailability: 47%
The estimate for compound 3 lay 25 percentage points below the measured number; the measured number lies above the stated range.
By their numbers in this assay, from the lowest: compounds 2 and 1 (each within the scatter of the next); then compound 3.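

In this assay the side chain on this saturated ring carbon clearly matters: pentan-3-yl in place of isobutyl brings a number 21 percentage points higher from compound 1 to compound 3 (beyond the scatter) and this step lies beyond the scatter. Exchanging one carbon-only chain for another, neither with a ring, is therefore enough to move oral bioavailability in the dog. Nothing available explains the rise.

This is a single swap, so it gives no trend across side chains. Going by these compounds, how a cyclopentyl ring or a chain carrying an amine would behave on this ring carbon remains open.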